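A trifluoromethyl exchange on compound 1

A few compounds are considered here, and "the series" means these few. Any claim that something is new, unique, unknown or untested is made for them only; others in the source may bear on it.

Compound 1 `CC(=O)Oc1ccc2c(c1)C(C)=CC(C)(C)N2Cc1ccccc1` gives 24000 nM
Compound 2 `CC(=O)Oc1ccc2c(c1)C(C)=CC(C)(C)N2Cc1cccc(C(F)(F)F)c1` gives 27000 nM

In an ADME assay on L6 cells (Rattus norvegicus) for cytotoxicity, read by resazurin assay, with a stated time of 70 h (a lower number here means a stronger inhibitor, a higher number a weaker inhibitor), compound 1 stands at 24000 nM and compound 2 at 27000 nM within the scatter of each other, so neither stands apart. Compound 3 `CC(=O)Oc1ccc2c(c1)C(C)=CC(C)(C)N2Cc1ccc(C(F)(F)F)cc1` differs from compound 1 by trifluoromethyl in place of hydrogen on an aromatic carbon as trifluoromethyl in place of hydrogen on an aromatic carbon, para to a large group. Within the data shown here, the same exchange at another aromatic carbon gave a 1.1-fold higher number from compound 1 to compound 2 (0.05 log units; within the scatter) as the only measured step bearing on it, so no step beyond the scatter is expected in this assay for compound 3. What is expected is a 1.0-fold higher number from compound 1 to compound 3 (0.02 log units; within the scatter) and nothing larger. Compound 3 is estimated at 25000 nM with 13000 nM to 48000 nM as the expected range.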

Compound 3, half-maximal inhibitory concentration: 14000 nM
The estimate for compound 3 lay 1.8-fold (0.25 log units) above the measured number; the measured number falls inside the stated range.
By their numbers in this assay, from the lowest: compounds 3, 1 and 2 (each within the scatter of the next).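

In this assay the exchange of hydrogen for trifluoromethyl, para to a large group, gives a 1.7-fold lower number from compound 1 to compound 3 (0.23 log units; within the scatter) and so brings no step beyond the scatter at this position. The same exchange has now been seen at two aromatic carbons of the benzyl ring of compound 1, and neither step stands apart from the scatter. Nothing in the data shown accounts for the result. The compounds shown leave open whether an amine or a carboxylic acid at this position would move the number beyond the scatter.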